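Isopropyl Replaces an Aryl Group on a Weak Series

A few compounds are considered here, and "the series" means these few. Any claim that something is new, unique, unknown or untested is made for them only; others in the source may bear on it.

Measured so far:
Compound 1 `COc1ncc(-c2ccc3c(c2)N(c2ccc(C)cc2)C(=O)CO3)cc1NS(=O)(=O)c1ccc(F)cc1` gives 28300 nM in a functional assay on HepG2 cells (Homo sapiens) for antiproliferative activity, read by MTT assay, with a stated time of 72 h; a lower number here means a stronger inhibitor, a higher number a weaker inhibitor.
Compound 2 `COc1cccc(N2C(=O)COc3ccc(-c4cnc(Cl)c(NS(=O)(=O)c5ccc(F)cc5)c4)cc32)c1` gives > 40000 nM in this assay, which is a limit of the assay and not a number.
Compound 3 `COc1cccc(N2C(=O)COc3ccc(-c4cnc(OC)c(NS(=O)(=O)c5ccc(F)cc5)c4)cc32)c1` gives > 40000 nM in this assay, again a limit rather than a number.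

Compound 2 therefore stands at the limit of > 40000 nM in this assay, at which 2 of the 3 values shown sit. The step to compound 4 `CC(C)N1C(=O)COc2ccc(-c3cnc(Cl)c(NS(=O)(=O)c4ccc(F)cc4)c3)cc21` changes the group on the ring nitrogen: isopropyl in place of 3-methoxyphenyl on an amide-type nitrogen in a ring. For the measured compounds named here, two measured steps touch this region. Between compound 1 and compound 3 the group on the same nitrogen was exchanged, giving an at least 1.4-fold higher number from compound 1 to compound 3 (0.15 log units; that floor lies within the scatter). The step that the two limits leave unreadable from compound 2 to compound 3 is likewise unreadable, since both ends sit at the limit. Going by the values given here, no measured step here swaps an aromatic group for an alkyl one, so the direction of the change remains open. Given that compound 2 itself is only a limit, compound 4 is expected to show a number no higher from compound 2 to compound 4 (the limit leaves the size open). Compound 4 is estimated at 40000 nM, in the range 15000 nM to 100000 nM, with a high chance that only a limit is reported.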

Compound 4, half-maximal inhibitory concentration: 21500 nM
For compound 4 the middle estimate is 1.9-fold (0.27 log units) above the measured one; measured number inside the range.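

For the compounds shown here, compound 4 shows that the amide-type nitrogen can carry isopropyl, a group with no ring, and still give a readable number in this assay, whereas the earlier compounds all carried an aromatic group there. The exchange gives an at least 1.8-fold lower number from compound 2 to compound 4 (0.26 log units; that floor lies within the scatter), so the data do not establish a gain beyond the usual scatter, although the true size of the step could be larger. The size stays open on one side, as the value of compound 2 is a limit of the assay and not a number: the limit of > 40000 nM in this assay, at which 2 of the 4 values shown sit.

The compounds shown leave open whether a methyl group, or a longer chain ending in an amine, on this nitrogen would move the number further. They also leave open whether isopropyl would give a similar result with methoxy in place of chloro on the aromatic carbon.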